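The source may hold more compounds than are shown below. What is called first, only, known or untested is meant among the compounds shown, and "the series" means these compounds.

Measured compounds:
- compound 1, `Cc1ccccc1-n1cc(COc2cccc(NC(=O)Nc3ccc(Cl)c(C(F)(F)F)c3)c2)nn1`, gives 3440 nM in a functional assay on HepG2 cells (Homo sapiens) for inhibition, read by MTT assay, with a stated time of 72 h; on this read-out lower numbers stand for stronger inhibition and higher numbers for weaker inhibition
- compound 2, `O=C(Nc1cccc(OCc2cn(-c3cccc(F)c3)nn2)c1)Nc1ccc(Cl)c(C(F)(F)F)c1`, gives 2120 nM in this assay
- compound 3, `O=C(Nc1cccc(OCc2cn(-c3ccccc3Br)nn2)c1)Nc1ccc(Cl)c(C(F)(F)F)c1`, gives 2810 nM in this assay

Compound 3 sits second highest of the three numbers in this assay; its nearest neighbour is compound 1 with a 1.2-fold lower number from compound 1 to compound 3 (0.09 log units; within the scatter), and the step of a 1.3-fold higher number from compound 2 to compound 3 (0.12 log units; within the scatter) is also within the scatter, so the three compounds cannot be ordered on these data.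

Compound 4, `O=C(Nc1cccc(OCc2cn(-c3cccc(Br)c3)nn2)c1)Nc1ccc(Cl)c(C(F)(F)F)c1`, is the next member. It differs from compound 3 by 3-bromophenyl in place of 2-bromophenyl on an aromatic nitrogen, the same atoms joined differently. For the measured compounds named here, the steps that bear on a change of the aryl group on the aromatic nitrogen are a 1.6-fold lower number from compound 1 to compound 2 (0.21 log units; within the scatter), a 1.3-fold higher number from compound 2 to compound 3 (0.12 log units; within the scatter) and a 1.2-fold lower number from compound 1 to compound 3 (0.09 log units; within the scatter): each within the scatter. Going by the values given here, nothing among the measured compounds points to a move beyond the scatter in this assay for this change, so the expected step is a 1.1-fold lower number from compound 3 to compound 4 (0.03 log units; within the scatter), no direction being favoured. Compound 4 is therefore estimated at 2600 nM in this assay, with a range from 1300 nM to 5200 nM.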

Compound 4, half-maximal inhibitory concentration: 1040 nM
Beside the measured number, compound 4's estimate is 2.5-fold (0.40 log units) above it, outside the stated range (below it).
By their numbers in this assay, from the lowest: compound 4; then compounds 2, 3 and 1 (each within the scatter of the next).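

In this assay, for the compounds shown here, the step from 2-bromophenyl to 3-bromophenyl on the aromatic nitrogen gives a 2.7-fold lower number from compound 3 to compound 4 (0.43 log units; beyond the scatter) and is the first step to lie beyond the scatter, with the same atoms joined differently. Going by these compounds alone, compound 4 also separates from the other two aryl variants, with a 2.0-fold lower number from compound 2 to compound 4 (0.31 log units; beyond the scatter) for bromo in place of fluoro and a 3.3-fold lower number from compound 1 to compound 4 (0.52 log units; beyond the scatter) for 3-bromophenyl in place of 2-methylphenyl, so the aryl group on this nitrogen does affect the number, although the earlier steps did not show it. Nothing measured here accounts for these steps.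

On these data alone, this rests on a single pair of bromo isomers, so whether 3-methylphenyl would show the same gain over 2-methylphenyl remains open. Also open, as far as these compounds go, is how an amine or a carboxylic acid on this phenyl ring would compare with bromo.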